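The source may report more compounds than this note shows. Statements on the series, on what has been measured and on what is new or still open speak of the compounds shown alone.

Measured so far:
compound 1, `CC1CC(C(=O)N2CCc3nc(C#Cc4ccccc4)sc3C2)C1`, 81 nM in an assay on HEK293 cells for positive allosteric modulation of metabotropic glutamate receptor 5 (Homo sapiens), read by FLIPR, with a stated time of 1 h; a higher number here means that more compound is needed for the effect, a lower number that less compound is needed
compound 2, `Cc1cccc(C(=O)N2CCc3nc(C#Cc4ccccc4)sc3C2)n1`, 160 nM in this assay

Compound 1 has the lowest of these two numbers, and compound 2 sits within the scatter of it: a 2.0-fold higher number from compound 1 to compound 2 (0.30 log units; within the scatter). Compound 3, `CC(C)S(=O)(=O)N1CCc2nc(C#Cc3ccccc3)sc2C1`, differs from compound 1 in one place: isopropylsulfonyl in place of (3-methylcyclobutyl)carbonyl on an amine nitrogen in a ring. Going by the values given here, the only measured step, from compound 1 to compound 2, changes the group on the carbonyl carbon and leaves the carbonyl itself; here the whole carbonyl group leaves and a sulfonyl enters, so that step gives only indirect guidance and no direction. The expected step is therefore small, a 1.9-fold higher number from compound 1 to compound 3 (0.27 log units; within the scatter), and compound 3 is estimated at 150 nM, with a range from 50 nM to 500 nM.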

Compound 3, half-maximal effective concentration: > 10000 nM
Compound 3: a limit, no number; the forecaster's own chance of this, stated with the estimate: 5%; middle value at least 66-fold (1.82 log units) away from the limit.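

Replacing the (3-methylcyclobutyl)carbonyl on the amine nitrogen with isopropylsulfonyl gives an at least 120-fold higher number from compound 1 to compound 3 (2.09 log units; beyond the scatter). Changing only the group on the carbonyl carbon had stayed small, with a 2.0-fold higher number from compound 1 to compound 2 (0.30 log units; within the scatter), so this position can respond far more strongly when the carbonyl itself is replaced. Compound 3 gives a limit and not a number: the limit of > 10000 nM in this assay, at which 1 of the 3 values shown sits.

This step changes the link and the group on it together, and the compounds shown cannot separate the two. An isopropylcarbonyl or a (3-methylcyclobutyl)sulfonyl group on the same nitrogen would tell them apart.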